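The compounds below may be only part of what the source reports. "The series", "measured", "known", "first", "only" and "open" are said of these compounds alone.

Measured in a functional assay on HepG2 cells (Homo sapiens) for antiproliferative activity, read by MTT assay, with a stated time of 24 h; a lower number here means a stronger inhibitor, a higher number a weaker inhibitor:
compound 1 `Cc1ccc(-c2nn(-c3ccccc3)cc2-c2nc3ccccc3n2S(=O)(=O)c2ccc(F)cc2)cc1`: 5060 nM
compound 2 `COc1ccc(S(=O)(=O)n2c(-c3cn(-c4ccccc4)nc3-c3ccc(F)cc3)nc3ccccc32)cc1`: 470 nM

Compound 2 has the lower of the two numbers, which makes it the stronger inhibitor, and the gap lies beyond the scatter. Compound 3 `O=S(=O)(c1ccc(F)cc1)n1c(-c2cn(-c3ccccc3)nc2-c2ccc(F)cc2)nc2ccccc21` is compound 2 with one change: fluoro in place of methoxy on an aromatic carbon. Compound 1 also carries (4-fluorophenyl)sulfonyl and gives 5060 nM, but it differs elsewhere too, so only part of that gap is expected to carry over. The expected change is a 2.8-fold higher number from compound 2 to compound 3 (0.44 log units; beyond the scatter), a moderate rise probably beyond the scatter. For compound 3 the estimated value is 1300 nM, with an expected range of 300 nM to 5500 nM.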

Compound 3, half-maximal inhibitory concentration: 3520 nM
For compound 3 the middle estimate is 2.7-fold (0.43 log units) below the measured one; measured number inside the range.
By their numbers in this assay, from the lowest: compound 2; then compounds 3 and 1 (each within the scatter of the next).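

On the sulfonyl-bearing aromatic ring, fluoro in place of methoxy gives a 7.5-fold higher number from compound 2 to compound 3 (0.87 log units; beyond the scatter), so this position responds to the change and methoxy is the better of the two groups tested there. At a different place, fluoro in place of methyl gives a 1.4-fold lower number from compound 1 to compound 3 (0.16 log units; within the scatter), so compound 1 and compound 3 cannot be told apart. Nothing here explains why methoxy outperforms fluoro. Going by these compounds, whether a hydroxyl, an amine or a longer ethoxy chain at this position would match methoxy stays open. So does whether methoxy would keep its advantage on the core of compound 1.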